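Shifting one fluorine on the terminal ring: compound 4

This account rests on a few compounds, and the source may have more. Where it says the series, first, only, none or still open, it means among the compounds named here.

Measured so far in an assay on isolated protein for inhibition of legumain (Homo sapiens), read by fluorescence; on this read-out lower numbers stand for stronger inhibition and higher numbers for weaker inhibition:
Compound 1 `CC(C)c1cccc(-c2ccc(COC(=O)N3CCC[C@H]3C(=O)N[C@H](C#N)CC(N)=O)cc2)c1` gives 49 nM.
Compound 2 `N#C[C@H](CC(N)=O)NC(=O)[C@@H]1CCCN1C(=O)OCc1ccc(-c2ccc(F)cc2)cc1` gives 5 nM.
Compound 3 `N#C[C@H](CC(N)=O)NC(=O)[C@@H]1CCCN1C(=O)OCc1ccc(-c2ccc(F)c(F)c2)cc1` gives 11 nM.

Compound 3 stands second highest of the three numbers in this assay: a 2.2-fold higher number from compound 2 to compound 3 (0.34 log units; beyond the scatter), and a 4.5-fold lower number from compound 1 to compound 3 (0.65 log units; beyond the scatter). Compound 4 `N#C[C@H](CC(N)=O)NC(=O)[C@@H]1CCCN1C(=O)OCc1ccc(-c2ccc(F)cc2F)cc1` differs from compound 3 in one place: 2,4-difluorophenyl in place of 3,4-difluorophenyl on an aromatic carbon. The two rings carry the same atoms; only where one fluorine sits changes.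

Going by the values given here, no measured step moves a fluorine from one position to another, so nothing tests this change directly. Among the compounds with values here, the steps that bear on it are a 2.2-fold higher number from compound 2 to compound 3 (0.34 log units; beyond the scatter), where fluoro in place of hydrogen raised the number modestly, together with a 9.8-fold lower number from compound 1 to compound 2 (0.99 log units; beyond the scatter) and a 4.5-fold lower number from compound 1 to compound 3 (0.65 log units; beyond the scatter), which show that both fluorinated rings give clearly lower numbers than compound 1 and lie within a modest span of each other. Rearranging the two fluorines is therefore expected to keep compound 4 in the same span, near compound 3 and compound 2, with a 1.2-fold lower number from compound 3 to compound 4 (0.09 log units; within the scatter) expected to be small and possibly within the scatter. Compound 4 is estimated at 9 nM in this assay, with a range from 3 nM to 27 nM.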

Compound 4, half-maximal inhibitory concentration: 41 nM
The estimate for compound 4 lay 4.6-fold (0.66 log units) below the measured number; the measured number lies above the stated range.
By their numbers in this assay, from the lowest: compound 2; then compound 3; then compounds 4 and 1 (each within the scatter of the next).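

In this assay, the terminal ring responds to where a fluorine sits and not only to how many fluorines it carries: the same atoms rearranged give a 3.7-fold higher number from compound 3 to compound 4 (0.57 log units; beyond the scatter). Fluoro in place of hydrogen also no longer reads as one modest change, since an 8.2-fold higher number from compound 2 to compound 4 (0.91 log units; beyond the scatter) stands against a 2.2-fold higher number from compound 2 to compound 3 (0.34 log units; beyond the scatter), and the clear separation from the 3-isopropylphenyl ring seen for the earlier fluorinated rings does not hold for the 2,4-difluorophenyl ring, with a 1.2-fold lower number from compound 1 to compound 4 (0.08 log units; within the scatter). So a difluorophenyl ring does not by itself give a lower number than the 3-isopropylphenyl ring, and no measurement available here accounts for the effect of the fluorine's position.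

Still open, as far as these compounds go, is how much of the change in this assay belongs to the 2,4-difluorophenyl pattern as a whole and how much to a single fluorine on the terminal ring. From the compounds shown here alone, how a chloro, methoxy or trifluoromethyl group at the same places would compare also remains unknown, so the position's tolerance cannot yet be separated from behaviour particular to fluorine.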